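Replacing a Pyridine Amide with a Pyridylmethyl Amide

The source may report more compounds than this note shows. Statements on the series, on what has been measured and on what is new or still open speak of the compounds shown alone.

Compound 2 `O=C(CCCCCCCCc1cn(-c2cnc3ccccc3c2)nn1)Nc1ccncc1` has been tested in a functional assay on SH-SY5Y cells (Homo sapiens) for cytotoxicity, read by MTT assay, with a stated time of 48 h, tested at 1 uM (on this read-out higher numbers stand for a weaker effect at the one concentration tested and lower numbers for a stronger effect), and gives 104%. That is the higher of the two numbers measured here. The other measured compound, compound 1 `O=C(CCCCCCCc1cn(-c2ccccc2-c2ccccc2)nn1)Nc1ccncc1`, gives 82% in this assay, a number that lies below compound 2 by more than the scatter of repeated runs. These two compounds differ in more than one place, so nothing can be said about what any single change does.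

Compound 3 `O=C(CCCCCCCCc1cn(-c2cnc3ccccc3c2)nn1)NCc1cccnc1` is not yet measured. It differs from compound 2 in one place: (pyridin-3-yl)methyl in place of pyridin-4-yl on an amide-type nitrogen. Going by the values given here, no pair of measured compounds shows this change, so its effect on the read-out is unknown. Compound 2 already sits where the cells show hardly any loss of viability at the one concentration used, leaving little room for a move upward. For compound 3 the expectation is therefore a value close to that of compound 2. The expected step of a number 5 percentage points lower from compound 2 to compound 3 (within the scatter) is none beyond the scatter. Compound 3 is estimated at 99%, with a range from 84% to 112%.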

Compound 3, a percentage reported as activity, at one concentration (the size of the read-out at that concentration, not a potency): 102%
Compound 3: the middle estimate sits 3 percentage points below what was measured; measured number inside the range.
By their numbers in this assay, from the lowest: compound 1; then compounds 3 and 2 (each within the scatter of the next).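

Placing (pyridin-3-yl)methyl in place of pyridin-4-yl on the amide-type nitrogen gives a number 2 percentage points lower from compound 2 to compound 3 (within the scatter) in this assay, the first single change that can be read in this set. At this one concentration, the amide-type nitrogen accepts the larger group with no difference from the pyridin-4-yl compound that repeated runs could separate, so compound 3, like compound 2, shows hardly any loss of viability. The data shown give no measured property or other evidence that could explain this result.

This single step combines two differences, an added carbon link and a different attachment point on the pyridine ring, so a (pyridin-4-yl)methyl group would be needed to tell them apart, while a 2-(pyridin-3-yl)ethyl group would test a longer chain at the same place. Going by these compounds, it also remains open whether the same swap would read alike on the core of compound 1, or at a higher concentration, where the cells might have more viability to lose.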